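Two Weakly Active Analogues and an Untested Dichlorobenzyl Variant

The source may hold more compounds than are shown below. What is called first, only, known or untested is meant among the compounds shown, and "the series" means these compounds.

Measured compounds:
Compound 1, `O=C(NOCc1ccc(Cl)cc1Cl)c1cn(-c2ccccc2)nc1-c1ccc(Cl)cc1`: 16200 nM
Compound 2, `O=C(NOCc1ccccc1)c1cn(-c2ccccc2)nc1-c1ccc(F)cc1`: 15300 nM

In a functional assay on MCF7 cells (Homo sapiens) for antiproliferative activity, read by MTT assay, with a stated time of 48 h, in the presence of a further agent that is not named here (on this read-out lower numbers stand for stronger inhibition of growth and higher numbers for weaker inhibition of growth), compound 1 gives 16200 nM, and compound 2 gives 15300 nM. Compound 2 stands alongside compound 1, the two numbers lying within the usual scatter of each other, so neither can be called more active. Compound 3, `O=C(NOCc1ccc(Cl)cc1Cl)c1cn(-c2ccccc2)nc1-c1ccc(F)cc1`, has not yet been measured. It differs from compound 2 in one place: 2,4-dichlorophenyl in place of phenyl on a saturated chain carbon bound to an oxygen. Compound 1 carries the same 2,4-dichlorobenzyl group, and its value in this assay is no different from that of compound 2 beyond the scatter, which gives no reason to expect a large step. The change from compound 2 to compound 3 is therefore expected to be a 1.0-fold higher number from compound 2 to compound 3 (0.01 log units; within the scatter), a step within the scatter in either direction. Compound 3 is estimated at 15500 nM in this assay, with a likely range from 7500 nM to 32000 nM.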

Compound 3, concentration for 50% growth inhibition: 25300 nM
For compound 3 the middle estimate is 1.6-fold (0.21 log units) below the measured one; the range from low to high includes it.
By their numbers in this assay, from the lowest: compounds 2, 1 and 3 (each within the scatter of the next).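

In this assay, going by these compounds alone, the first one-place reading at this site is a 1.7-fold higher number from compound 2 to compound 3 (0.22 log units; within the scatter) when 2,4-dichlorophenyl replaces phenyl on a saturated chain carbon bound to an oxygen, so this change cannot be told apart from repeat-measurement noise. Compound 3 also allows a one-place reading at a second site, as fluoro in place of chloro on an aromatic carbon gives a 1.6-fold higher number from compound 1 to compound 3 (0.19 log units; within the scatter) and likewise stays inside the noise, so neither change separates from the scatter in these three compounds. No independent evidence bears on these results.

The compounds shown leave open whether any change at the benzyl group can produce a clear step, for example a methoxy group or an amine on its ring, or a longer chain between the oxygen and the ring. They also leave open whether a group such as a carboxylic acid on the shared core would do so.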